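Cytotoxicity of oxazole-piperidine amides: moving to dimethoxyphenyl

The source may report more compounds than this note shows. Statements on the series, on what has been measured and on what is new or still open speak of the compounds shown alone.

Measured compounds:
compound 1 `Cc1oc(-c2c(F)cccc2F)nc1CN1CCC(C(=O)NCCCN2C[C@H](C)C[C@H](C)C2)CC1`: 32700 nM
compound 2 `Cc1oc(-c2c(Br)cccc2Br)nc1CN1CCC(C(=O)NCCCN2C[C@H](C)C[C@H](C)C2)CC1`: 6500 nM
compound 3 `Cc1ccc(-c2nc(CN3CCC(C(=O)NCCCN4C[C@H](C)C[C@H](C)C4)CC3)c(C)o2)cc1`: 4330 nM

Three compounds with a shared core differ only in the aryl group on the five-membered ring. In an ADME assay on Huh7.5.1 cells (Homo sapiens) for cytotoxicity, read by ATP content, with a stated time of 48 h (a higher number here means that more compound is tolerated, a lower number that less compound is tolerated), compound 1 gives 32700 nM, compound 2 gives 6500 nM and compound 3 gives 4330 nM. Compound 3 has the lowest of the three numbers; its gap to compound 2 is within the scatter, while its gap to compound 1 is beyond it.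

Compound 4 `COc1ccc(-c2nc(CN3CCC(C(=O)NCCCN4C[C@H](C)C[C@H](C)C4)CC3)c(C)o2)cc1OC` is the next step from compound 3: 3,4-dimethoxyphenyl in place of 4-methylphenyl on an aromatic carbon.

All three measured steps vary the same aryl group and so bear on this one. The step of a 5.0-fold lower number from compound 1 to compound 2 (0.70 log units; beyond the scatter) and the step of a 7.6-fold lower number from compound 1 to compound 3 (0.88 log units; beyond the scatter) were both modest but beyond the scatter, whereas the step of a 1.5-fold lower number from compound 2 to compound 3 (0.18 log units; within the scatter) stayed within it. Within the data shown here, no measured step introduces methoxy groups, so the direction cannot be read from precedent; an aryl swap of this kind has moved this assay by modest amounts at most. The step from compound 3 to compound 4 is therefore expected to be small, a 1.4-fold higher number from compound 3 to compound 4 (0.14 log units; within the scatter), with no confident direction. In this assay compound 4 is estimated at 6000 nM, within a range of 2500 nM to 15000 nM.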

Compound 4, half-maximal cytotoxic concentration: 57200 nM
Beside the measured number, compound 4's estimate is 9.5-fold (0.98 log units) below it; measured number outside the range, above it.
By their numbers in this assay, from the lowest: compounds 3 and 2 (each within the scatter of the next); then compounds 1 and 4 (each within the scatter of the next).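

In this assay, the aryl group on the five-membered ring proves able to move the number much further than the earlier swaps suggested: a 13-fold higher number from compound 3 to compound 4 (1.12 log units; beyond the scatter) is a large step, whereas no earlier swap at this position went beyond modest. The 3,4-dimethoxyphenyl group also separates from the 2,6-dibromophenyl group, an 8.8-fold higher number from compound 2 to compound 4 (0.94 log units; beyond the scatter), but a 1.7-fold higher number from compound 1 to compound 4 (0.24 log units; within the scatter), so it cannot be told apart from the 2,6-difluorophenyl group, and two quite different aryl groups thus share the tolerated end of this small series. Nothing available gives a reason for the size of this step or shows which feature of the 3,4-dimethoxyphenyl group matters.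

As far as these compounds go, it remains open whether both methoxy groups are needed, or whether a single one, as in 4-methoxyphenyl, or a hydroxyl group or an amine on the phenyl ring would shift the number in this assay in the same way. The compounds shown also leave open whether the step would carry over to a different amide chain on the shared core.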